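The source may hold more compounds than are shown below. What is called first, only, known or untested is meant among the compounds shown, and "the series" means these compounds.

Of the compounds shown here, three built on one shared core have been measured in a functional assay on cells for antagonist activity at prostaglandin D2 receptor 2 (Homo sapiens), read by flow cytometry, with a stated time of 10 min; a lower number here means a stronger inhibitor, a higher number a weaker inhibitor. Compound 1, `O=C(O)COc1ccc(Cl)cc1C#Cc1ccc(CO)cc1F`, gives 680 nM. Compound 2, `CCCS(=O)(=O)c1ccc(F)c(C#Cc2cc(Cl)ccc2OCC(=O)O)c1`, gives 23 nM. Compound 3, `Cc1ccc(S(=O)(=O)N(C)C(C)C)cc1C#Cc1cc(Cl)ccc1OCC(=O)O`, gives 140 nM, which is the second highest of the three numbers: its step to compound 1 and its step to compound 2 both lie beyond the usual scatter of this assay.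

Compound 4, `Cc1ccc(S(=O)(=O)NC(C)C)cc1C#Cc1cc(Cl)ccc1OCC(=O)O`, differs from compound 3 in one place: hydrogen in place of methyl on a sulfonamide nitrogen. Among the compounds with values here, no measured pair shows this exact change, so there is no step to lean on. The expectation is a step from compound 3 to compound 4 of no change at the digits printed from compound 3 to compound 4 (within the scatter), small enough that it may not rise above the scatter. Compound 4 is therefore estimated at 140 nM, with a range from 50 nM to 400 nM.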

Compound 4, half-maximal inhibitory concentration: 250 nM
Beside the measured number, compound 4's estimate is 1.8-fold (0.25 log units) below it; measured number inside the range.
By their numbers in this assay, from the lowest: compound 2; then compounds 3 and 4 (each within the scatter of the next); then compound 1.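

In this assay, within the data shown here, this is the first pair of compounds that differ in only one place, which isolates the sulfonamide nitrogen. Hydrogen in place of methyl there gives a 1.8-fold higher number from compound 3 to compound 4 (0.25 log units; within the scatter), so the two compounds cannot be told apart, and the methyl is not shown to matter for this read-out. As far as these compounds go, whether an ethyl group on this nitrogen, or a morpholine ring in place of the whole isopropylamino group, would give a clear step remains open. Nothing available here offers a reason for this result.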